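Carboxy to (dimethylamino)methyl exchange on two chain lengths

This account rests on a few compounds, and the source may have more. Where it says the series, first, only, none or still open, it means among the compounds named here.

Measured compounds:
compound 1 `CN(C)CCCn1c(Cc2nn(C)c(=O)c3ccccc23)nnc1SCCCCCCCC(=O)Nc1ccc(Cl)cc1Cl`: 3700 nM
compound 2 `Cn1nc(Cc2nnc(SCCCCCCCC(=O)Nc3ccc(Cl)cc3Cl)n2CCC(=O)O)c2ccccc2c1=O`: 23500 nM
compound 3 `Cn1c(Cc2nn(CCC(=O)O)c(=O)c3ccccc23)nnc1SCC(=O)Nc1ccc(Cl)cc1Cl`: a limit only, > 30000 nM

In an assay on 32D cells for inhibition of interleukin-15 (Mus musculus), read by resazurin assay, with stated times of 30 min and 2.5 days, in the presence of a further agent that is not named here (on this read-out lower numbers stand for stronger inhibition and higher numbers for weaker inhibition), compound 1 gives 3700 nM and compound 2 gives 23500 nM. Compound 3 reaches only the assay limit, > 30000 nM, which is a limit and not a number (the limit of > 30000 nM in this assay, at which 1 of the 3 values shown sits). The change (dimethylamino)methyl in place of carboxy on a saturated chain carbon, two bonds along the chain from an aromatic nitrogen produces a 6.4-fold lower number from compound 2 to compound 1 (0.80 log units; beyond the scatter). Compound 4 `CN(C)CCCn1nc(Cc2nnc(SCC(=O)Nc3ccc(Cl)cc3Cl)n2C)c2ccccc2c1=O` carries the same change, ((dimethylamino)methyl in place of carboxy on a saturated chain carbon, two bonds along the chain from an aromatic nitrogen), on the core of compound 3; how that core differs from the core of compound 2 is not broken down here. Compound 4 is expected to show an at least 3.3-fold lower number from compound 3 to compound 4 (0.52 log units; beyond the scatter) in this assay, resting on a 6.4-fold lower number from compound 2 to compound 1 (0.80 log units; beyond the scatter). For compound 4 the estimate is 9000 nM, expected to fall between 2500 nM and 30000 nM. Because compound 3 stands at a limit (the limit of > 30000 nM in this assay, at which 1 of the 3 values shown sits), the starting point is uncertain, and a limit for compound 4 remains possible.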

Compound 4, half-maximal inhibitory concentration: 18800 nM
Beside the measured number, compound 4's estimate is 2.1-fold (0.32 log units) below it; the measured number falls inside the stated range.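

In this assay the exchange of carboxy for (dimethylamino)methyl on the core of compound 3 gives an at least 1.5-fold lower number from compound 3 to compound 4 (0.20 log units; that floor lies within the scatter). The change points the same way on both cores, but its floor here does not establish a real shift, and its size cannot be compared between them: the same change on two cores in this assay, a 6.4-fold lower number (0.80 log units; beyond the scatter) from compound 2 to compound 1 and an at least 1.5-fold lower number (0.20 log units; that floor lies within the scatter) from compound 3 to compound 4; the limit leaves it open whether they differ Compound 3 gives a limit and not a number, so the notes support no fixed size for this change on a new core: the limit of > 30000 nM in this assay, at which 1 of the 4 values shown sits.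

From the compounds shown here alone, it remains open whether the lower numbers follow the entry of the dimethylamino group or the departure of the carboxy group. A primary amide or a primary amine on the same chain, on both cores, would separate these two readings.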